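This account rests on a few compounds, and the source may have more. Where it says the series, first, only, none or still open, it means among the compounds named here.

Working notes on a series sharing one core. Compound 1 `CCC1(Cc2ccccc2)OS(=O)(=O)C=C1OCc1ccc([N+](=O)[O-])cc1` carries nitro on an aromatic carbon; in an ADME assay on HEL cells (Homo sapiens) for cytotoxicity, with a stated time of 3 days (a higher number here means that more compound is tolerated, a lower number that less compound is tolerated), compound 1 gives only a limit of the assay, < 200000 nM. Compound 2 `CCC1(Cc2ccccc2)OS(=O)(=O)C=C1OCc1ccc(C)cc1` carries methyl in that place, and in this assay compound 2 gives 41500 nM. Compound 3 `CCC1(Cc2ccccc2)OS(=O)(=O)C=C1OCc1ccc(F)cc1` carries fluoro there; in this assay compound 3 gives a limit of the assay, > 50000 nM, not a number. Among the three values shown, compound 3 therefore stands at a limit, with no number of its own. The steps from compound 1 are unreadable because of the limit of < 200000 nM in this assay, at which 1 of the 3 values shown sits: a step that the limit leaves unreadable from compound 1 to compound 2 and a step that the limit leaves unreadable from compound 1 to compound 3. For the measured compounds named here, the only readable step is an at least 1.2-fold higher number from compound 2 to compound 3 (0.08 log units; that floor lies within the scatter), and it carries only a floor because of the limit of > 50000 nM in this assay, at which 1 of the 3 values shown sits. Compound 4 `CCC1(Cc2ccccc2)OS(=O)(=O)C=C1OCc1ccc(C(C)(C)C)cc1` is the next member, differing from compound 3 by tert-butyl in place of fluoro on an aromatic carbon. Going by the values given here, no measured step exchanges fluoro for tert-butyl, so no direction in this assay can be read from the values shown, and no step beyond the scatter is expected with confidence. The estimate for compound 4 in this assay is 50000 nM, within 15000 nM to 150000 nM. That estimate means an expected step of a number no higher from compound 3 to compound 4 (the limit leaves the size open).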

Compound 4, half-maximal cytotoxic concentration: 200000 nM
For compound 4 the middle estimate is 4.0-fold (0.60 log units) below the measured one; the measured number lies above the stated range.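

In this assay, tert-butyl in place of methyl on the aromatic carbon gives a 4.8-fold higher number from compound 2 to compound 4 (0.68 log units; beyond the scatter), a modest step and the first at this position whose size can be read and which lies beyond the scatter. The number in this assay therefore does move with the group at this position, upward in this one pair, which alone sets no trend. Tert-butyl in place of nitro gives a number no lower from compound 1 to compound 4 (the limit leaves the size open). The step to compound 4 from compound 3 cannot be read.

From the compounds shown here alone, whether the rise from methyl to tert-butyl follows the count of carbon atoms in the group, for which isopropyl would be a test, remains open, as does whether it holds for an amine or a carboxylic acid at this position. Where fluoro and nitro stand relative to tert-butyl also remains open, with only limits for compound 3 and compound 1.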